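The source may report more compounds than this note shows. Statements on the series, on what has been measured and on what is new or still open speak of the compounds shown alone.

Series notes. Compound 1 `CN(C)c1ccc(C2CC(c3cc4ccccc4o3)=NN2C(=O)c2ccncc2)cc1` and compound 2 `O=C(c1ccncc1)N1N=C(c2cc3ccccc3o2)CC1c1ccc(Cl)cc1` share the core and differ in one place, chloro in place of dimethylamino on an aromatic carbon. In an ADME assay on Vero cells (Chlorocebus sabaeus) for cytotoxicity, read by MTT assay, with a stated time of 72 h (on this read-out higher numbers stand for weaker inhibition and lower numbers for stronger inhibition), compound 1 reaches only a limit, > 210000 nM. Compound 2 likewise reaches only a limit in this assay, > 220000 nM. The step that the two limits leave unreadable from compound 1 to compound 2 therefore cannot be read. Compound 1 sits at the limit of > 210000 nM in this assay, at which 1 of the 2 values shown sits. Compound 2 sits at the limit of > 220000 nM in this assay, at which 1 of the 2 values shown sits. Compound 2 thus stands at the edge of what this assay can report, with no number of its own.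

Compound 3 `O=C(c1ccncc1)N1N=C(c2cc3ccccc3o2)CC1c1ccccc1[N+](=O)[O-]` carries 2-nitrophenyl in place of 4-chlorophenyl on a saturated ring carbon. No measured step bears on this change; the one step shown is unreadable, so neither size nor direction can be taken from it. Compound 3 is expected to reach the limit again rather than a number, an expected step that the limit leaves unreadable from compound 2 to compound 3. Compound 3 is estimated at 250000 nM, between 60000 nM and 1000000 nM.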

Compound 3, half-maximal inhibitory concentration: > 245000 nM
Compound 3 gave a limit, no number; the forecaster's own chance of this, stated with the estimate: 85%; the middle value lies beyond the limit too.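

In this assay compound 3 gives > 245000 nM, a limit and not a number, so its steps from compound 1 and compound 2 cannot be read. The compounds shown leave open whether any change of the group on the saturated ring carbon alters this read-out.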